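Swapping the Pyrazinyl Ring of Compound 1 for Methylfuran

The source may hold more compounds than are shown below. What is called first, only, known or untested is meant among the compounds shown, and "the series" means these compounds.

Compound 1 `c1ccc(-c2cnccn2)c(OCC2=NCCN2)c1` is the weakest of three measured compounds in a functional assay with Alpha-1A adrenergic receptor (Homo sapiens) as the target, read by calcium flux (a higher number here means a larger maximal response, a lower number a smaller maximal response), where compound 1 reaches 97%. Compound 2 `c1coc(-c2ccccc2OCC2=NCCN2)c1` reaches 106%, a shift of a number 9 percentage points higher from compound 1 to compound 2 (within the scatter). Compound 3 `c1ccc(-c2cc[nH]n2)c(OCC2=NCCN2)c1` reaches 119%, a shift of a number 22 percentage points higher from compound 1 to compound 3 (beyond the scatter). The unmeasured compound 4 `Cc1ccoc1-c1ccccc1OCC1=NCCN1` differs from compound 1 in one place: 3-methylfuran-2-yl in place of pyrazin-2-yl on an aromatic carbon. Among the compounds with values here, the closest precedent is the step from compound 1 to compound 2, which put a furan-2-yl in place of the pyrazin-2-yl and stayed within the scatter. A 3-methylfuran-2-yl is expected to behave much like that plain furan, so no step beyond the scatter is expected: compound 4 is estimated to reach 104%, between 90% and 118%, an expected change of a number 7 percentage points higher from compound 1 to compound 4 (within the scatter).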

Compound 4, largest response reached (reported as maximum), in percent of the reference or control that the assay uses: 99%
The estimate for compound 4 lay 5 percentage points above the measured number; the measured number falls inside the stated range.
By their numbers in this assay, from the lowest: compounds 1, 4 and 2 (each within the scatter of the next); then compound 3.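

On this aromatic carbon, 3-methylfuran-2-yl and pyrazin-2-yl cannot be told apart in this assay (a number 2 percentage points higher from compound 1 to compound 4 (within the scatter)). Methyl in place of hydrogen on the furan, a change the earlier compounds did not include, also stays inside the noise (a number 7 percentage points lower from compound 2 to compound 4 (within the scatter)). Within the data shown here, the 1H-pyrazol-3-yl of compound 3 remains the one group that stands apart (a number 20 percentage points lower from compound 3 to compound 4 (beyond the scatter)).

Nothing at hand explains these numbers. Going by these compounds, what a morpholine or a simple amine would do on this aromatic carbon stays open.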